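The source may report more compounds than this note shows. Statements on the series, on what has been measured and on what is new or still open speak of the compounds shown alone.

Compound 1 `COc1ccc(S(=O)(=O)Nc2ccc3oc(-c4ccc(NC(=O)c5ccc(Cl)s5)cc4)nc3c2)cc1` — 61000 nM
Compound 2 `COc1ccc(S(=O)(=O)Nc2ccc3oc(-c4ccc(NS(=O)(=O)c5cc(Br)ccc5OC)cc4)nc3c2)cc1` — 67000 nM

In an assay on mitochondria for inhibition of HSP60/HSP10 (Homo sapiens) (a lower number here means a stronger inhibitor, a higher number a weaker inhibitor), compound 1 gives 61000 nM and compound 2 gives 67000 nM. Compound 2 stands beside compound 1 on these numbers, the step of a 1.1-fold higher number from compound 1 to compound 2 (0.04 log units; within the scatter) lying within the scatter.

Compound 3 `COc1ccc(S(=O)(=O)Nc2ccc3oc(-c4ccc(NS(=O)(=O)c5cc(F)ccc5OC)cc4)nc3c2)cc1` differs from compound 2 by fluoro in place of bromo on an aromatic carbon. Among the compounds with values here, no measured step swaps one halogen for another; the only measured step, a 1.1-fold higher number from compound 1 to compound 2 (0.04 log units; within the scatter), exchanged the whole group and was within the scatter, so it bears on this change only loosely. Compound 3 is therefore expected to show a step of a 1.2-fold higher number from compound 2 to compound 3 (0.08 log units; within the scatter) in this assay, not beyond the scatter. Compound 3 is estimated at 80000 nM, between 35000 nM and 180000 nM.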

Compound 3, half-maximal inhibitory concentration: > 100000 nM
Compound 3 ended at the assay's limit; the forecaster's own chance of this, stated with the estimate: 20%; at least 1.2-fold (0.09 log units) between middle value and limit.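

Within the data shown here, compound 3 stands at > 100000 nM in this assay, a limit of the assay and not a number, the only such reading here: the limit of > 100000 nM in this assay, at which 1 of the 3 values shown sits. Fluoro in place of bromo at this position gave no gain in inhibition, only an at least 1.4-fold higher number from compound 2 to compound 3 (0.17 log units; that floor lies within the scatter). Against the chlorothiophene amide, the 5-fluoro-2-methoxyphenyl sulfonyl group likewise gave only an at least 1.6-fold higher number from compound 1 to compound 3 (0.21 log units; that floor lies within the scatter), so neither floor separates compound 3 from the others.

From the compounds shown here alone, how far the true value of compound 3 lies past its limit stays open. Also open, going by these compounds, is whether an amine or a carboxylic acid at this position would bring any stronger inhibition.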